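This account rests on a few compounds, and the source may have more. Where it says the series, first, only, none or still open, it means among the compounds named here.

Measured so far in an ADME assay (liver) for metabolic stability, with Liver microsome (Homo sapiens) as the target, using microsomes; a lower number here means that the compound disappears faster, a higher number that the compound lasts longer:
- compound 1 `COc1cc(NC(=O)C2(NC(=O)c3ccc4c(C5CCCC5)c(-c5ccccn5)n(C)c4c3)CCC2)ccc1/C=C/C(=O)O`: 1.37 h
- compound 2 `Cn1c(-c2ccccn2)c(C2CCCC2)c2ccc(C(=O)NC3(C(=O)Nc4ccc(/C=C/C(=O)O)c(OC5CCC5)c4)CCC3)cc21`: 0.833 h

For the measured compounds named here, compound 2 holds the smaller of the two numbers, but the only step, a 1.6-fold lower number from compound 1 to compound 2 (0.22 log units; within the scatter), lies within the scatter, so the two compounds are not separated in this assay.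

Compound 3 `COCCOc1cc(NC(=O)C2(NC(=O)c3ccc4c(C5CCCC5)c(-c5ccccn5)n(C)c4c3)CCC2)ccc1/C=C/C(=O)O` differs from compound 2 by 2-methoxyethyl in place of cyclobutyl on an oxygen on an aromatic ring. Going by the values given here, no measured pair covers this exchange; the one step at this oxygen, a 1.6-fold lower number from compound 1 to compound 2 (0.22 log units; within the scatter), is within the scatter. A change no larger than the scatter is therefore expected, a 1.2-fold higher number from compound 2 to compound 3 (0.08 log units; within the scatter). Compound 3 is estimated at 1 h, with a range from 0.5 h to 2 h.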

Compound 3, half-life: 1.45 h
The estimate for compound 3 lay 1.5-fold (0.16 log units) below the measured number; low and high end bracket the measured number.
By their numbers in this assay, from the lowest: compounds 2, 1 and 3 (each within the scatter of the next).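

In this assay the steps of a 1.7-fold higher number from compound 2 to compound 3 (0.24 log units; within the scatter) and a 1.1-fold higher number from compound 1 to compound 3 (0.02 log units; within the scatter) show that this oxygen on an aromatic ring carries methyl, cyclobutyl or 2-methoxyethyl without any separation between the compounds. Replacing the four-membered ring with an open chain and adding one hydrogen-bond acceptor therefore gives no change beyond the scatter. No measurement at hand gives a reason for this.

Going by these compounds, whether a longer chain or a terminal amine on this oxygen would move the half-life beyond the scatter stays open. The same holds for a carboxylic acid there.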